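Replacing a nitro group with a hydroxy group

The source may report more compounds than this note shows. Statements on the series, on what has been measured and on what is new or still open speak of the compounds shown alone.

Measured so far in a functional assay on SGC-7901 cells (Homo sapiens) for antiproliferative activity, read by MTT assay, with a stated time of 72 h; on this read-out lower numbers stand for stronger inhibition and higher numbers for weaker inhibition
compound 1 `CCOC(=O)c1cc(-c2cc(OC)c(OC)c(OC)c2)c(-c2ccc(OC)c(O)c2)s1` gives 1580 nM
compound 2 `COc1ccc(-c2sccc2-c2cc(OC)c(OC)c(OC)c2)cc1` gives 5470 nM
compound 3 `COc1ccc(-c2sccc2-c2cc(OC)c(OC)c(OC)c2)cc1[N+](=O)[O-]` gives 3310 nM

Compound 3 (3310 nM) holds the second highest of the three numbers. It lies within the scatter of compound 2 (5470 nM), so these two cannot be ordered, while compound 1 (1580 nM) lies lower than compound 3, beyond the scatter.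

The next compound is compound 4 `COc1ccc(-c2sccc2-c2cc(OC)c(OC)c(OC)c2)cc1O`, which has hydroxy in place of nitro on an aromatic carbon. Among the measured compounds shown here, no measured step makes this exchange directly. For the measured compounds named here, the one step at this place (a 1.7-fold lower number from compound 2 to compound 3 (0.22 log units; within the scatter)) came with nitro in place of hydrogen on an aromatic carbon, so losing the nitro group alone is not expected to move the number beyond the scatter. Compound 1 also carries a hydroxy group ortho to a methoxy group, along with an ester that compound 4 lacks. The value of compound 1 (1580 nM) suggests that compound 4 may give a modestly lower number in this assay, though the ester leaves this uncertain. The expected change is a moderate one (a 2.5-fold lower number from compound 3 to compound 4 (0.41 log units; beyond the scatter)). The estimated value for compound 4 is 1300 nM (expected range 250 nM to 4500 nM).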

Compound 4, half-maximal inhibitory concentration: 580 nM
Compound 4: middle estimate off by 2.2-fold (0.35 log units), on the high side; the range from low to high includes it.
By their numbers in this assay, from the lowest: compound 4; then compound 1; then compounds 3 and 2 (each within the scatter of the next).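

In this assay, among the compounds shown here, the hydroxy group is the first change on this aromatic carbon, ortho to a methoxy group, to carry the number beyond the scatter: the exchange for nitro gives a 5.7-fold lower number from compound 3 to compound 4 (0.76 log units; beyond the scatter) and the exchange for hydrogen gives a 9.4-fold lower number from compound 2 to compound 4 (0.97 log units; beyond the scatter) while nitro in place of hydrogen had given only a 1.7-fold lower number from compound 2 to compound 3 (0.22 log units; within the scatter) and so left those two groups unordered. With the hydroxy group kept, removing the ethoxycarbonyl group also lowers the number, as a 2.7-fold lower number from compound 1 to compound 4 (0.44 log units; beyond the scatter) shows, so that ester is not required for a low number on this core, and compound 4 stands lowest of the four with all its steps beyond the scatter. Nothing available accounts for why the hydroxy group has this effect.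

The compounds shown leave open whether the hydroxy group itself is needed on this carbon, or whether an amine, a fluorine or a methoxy group there would give a similarly low number. They also leave open how a carboxylic acid or an amide would compare with hydrogen where compound 1 carries its ester.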